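Aryl variation on the hydrazone carbon of the shared core

A few compounds are considered here, and "the series" means these few. Any claim that something is new, unique, unknown or untested is made for them only; others in the source may bear on it.

Compound 1 `Cc1cccc(/C=N/Nc2ncc3c(n2)n(C2CCCC2)c(=O)c(=O)n3C)c1` carries 3-methylphenyl on a carbon with a double bond to nitrogen. In a functional assay on HCT-116 cells (Homo sapiens) for antiproliferative activity, read by MTT assay (a higher number here means a weaker inhibitor, a lower number a stronger inhibitor), compound 1 gives only a limit, > 100000 nM. Compound 2 `Cn1c(=O)c(=O)n(C2CCCC2)c2nc(N/N=C/c3ccc(F)cc3Br)ncc21` gives 8390 nM in this assay and compound 3 `Cn1c(=O)c(=O)n(C2CCCC2)c2nc(N/N=C/c3ccccc3F)ncc21` gives 20700 nM, so both halogenated aryl analogues give smaller numbers: an at least 11-fold lower number from compound 1 to compound 2 (1.07 log units; beyond the scatter) and an at least 4.8-fold lower number from compound 1 to compound 3 (0.68 log units; beyond the scatter), while a 2.5-fold higher number from compound 2 to compound 3 (0.39 log units; beyond the scatter). Compound 4 `CSc1ccc(/C=N/Nc2ncc3c(n2)n(C2CCCC2)c(=O)c(=O)n3C)cc1` differs from compound 1 by 4-(methylsulfanyl)phenyl in place of 3-methylphenyl on a carbon with a double bond to nitrogen. Both recorded swaps away from 3-methylphenyl lowered the number, so a step of the same sign is expected here, though the entering group is not a halogen and the size remains uncertain. The step expected from this change is an at least 3.3-fold lower number from compound 1 to compound 4 (0.52 log units; beyond the scatter). Compound 4 is expected to give 30000 nM in this assay, within 8000 nM to 100000 nM.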

Compound 4, half-maximal inhibitory concentration: 9010 nM
Beside the measured number, compound 4's estimate is 3.3-fold (0.52 log units) above it, and the stated range covers the measured number.
By their numbers in this assay, from the lowest: compounds 2 and 4 (each within the scatter of the next); then compound 3. At a limit, above all of these: compound 1.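

In this assay, 4-(methylsulfanyl)phenyl on a carbon with a double bond to nitrogen gives an at least 11-fold lower number from compound 1 to compound 4 (1.04 log units; beyond the scatter), so a halogen on the aryl group is not required for a lower number than the limit of compound 1. The same group gives a 2.3-fold lower number from compound 3 to compound 4 (0.36 log units; beyond the scatter), while a 1.1-fold higher number from compound 2 to compound 4 (0.03 log units; within the scatter), so a non-halogen aryl group and the 2-bromo-4-fluorophenyl group do not separate here.

On these data alone, compound 1 stands only as a limit, so the full size of its steps stays open: the limit of > 100000 nM in this assay, at which 1 of the 4 values shown sits. Whether an amine or a carboxylic acid on the aryl ring would keep these numbers also remains open.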